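A few compounds are considered here, and "the series" means these few. Any claim that something is new, unique, unknown or untested is made for them only; others in the source may bear on it.

Of the compounds shown here, three of a shared core have been measured so far. Compound 1 `CC(=O)c1cc(C=O)c(OCCCCC#N)cc1O` gives 3% in an assay on isolated protein for binding affinity to leukotriene B4 receptor 1 (Homo sapiens), tested at 1 uM; a higher number here means more inhibition at the concentration tested (going by the name of the read-out), a lower number less inhibition. Compound 2 `CCc1cc(C(C)=O)c(O)cc1OCCCCC(C)(C)C#N` gives 30% in this assay, and compound 3 `C=CCc1cc(C(C)=O)c(O)cc1OCCCCCC(C)=O` gives 58%. Among these three numbers compound 2 stands second highest: compound 1 sits below it by a gap beyond the usual scatter, and compound 3 sits above it by a gap that is also beyond the scatter. The three compounds differ from one another in more than one place, so no single change can be read off from them.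

Compound 4 `CCc1cc(C(C)=O)c(O)cc1OCCCCCn1cncn1` differs from compound 2 in one place: (1H-1,2,4-triazol-1-yl)methyl in place of 1-cyano-1-methylethyl on a saturated chain carbon, four bonds along the chain from an oxygen on an aromatic ring. Within the data shown here, no measured pair shows this particular change, so the direction and size of its effect in this assay are not known from the data. A group without a ring leaves and a five-membered aromatic ring with three hetero atoms enters at the same place on the chain; a step of modest size in either direction, or none beyond the scatter, is plausible.

Compound 4 is therefore expected to give about 35%, within a range from 10% to 65%, which means an estimated step of a number 5 percentage points higher from compound 2 to compound 4 (within the scatter).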

Compound 4, a percentage reported as inhibition, at one concentration (the size of the read-out at that concentration, not a potency): 30%
For compound 4 the middle estimate is 5 percentage points above the measured one, within the range that was stated.
By their numbers in this assay, from the lowest: compound 1; then compounds 2 and 4 (each within the scatter of the next); then compound 3.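

Replacing 1-cyano-1-methylethyl with (1H-1,2,4-triazol-1-yl)methyl on the saturated chain carbon, four bonds along the chain from an oxygen on an aromatic ring, gives no change at the digits printed from compound 2 to compound 4 (within the scatter) in this assay. Among these compounds, this is the first single-place comparison, and it shows that this place can carry a five-membered aromatic ring with 3 hetero atoms in place of a group with no ring and a triple bond without a step beyond the scatter, even though the count of hydrogen-bond acceptors goes from 1 to 3. The data offer no measurement that accounts for this match between the two groups.

One pair at a single test concentration cannot show whether other groups at this same place, such as an amine, a carboxylic acid or a longer chain, would leave the number where it is or move it. On these data alone, compounds 1 and 3 differ from compounds 2 and 4 in more than one place, so steps to them cannot be read, and how much of their numbers depends on the group at this place remains open.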